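Benzyl in place of 2-chlorophenyl in compound 4

The source may report more compounds than this note shows. Statements on the series, on what has been measured and on what is new or still open speak of the compounds shown alone.

Values in an ADME assay on S9 fraction from liver (Rattus norvegicus) for metabolic stability, read by LC-MS, using NADPH, with a stated time of 30 min; a higher number here means that more of the compound is left, a lower number that less of the compound is left:
Compound 1 `CCCCCCCCc1ccc(OCC(=O)Cn2nnc(SC)n2)cc1`: < 5%
Compound 2 `CCCCCCCCc1ccc(OCC(=O)Cn2nnnc2-c2ccccc2)cc1`: 36%
Compound 3 `CCCCCCCCc1ccc(OCC(=O)Cn2nnnc2-c2ccccc2Cl)cc1`: 42%

The value of compound 1 is a limit of the assay, not a number. Going by the values given here, compound 3 stands within the scatter of compound 2, the only other compound with a number. Compound 4 `CCCCCCCCc1ccc(OCC(=O)Cn2nnnc2Cc2ccccc2)cc1` carries benzyl in place of 2-chlorophenyl on an aromatic carbon. Among the compounds with values here, one measured step bears on this change, a number 6 percentage points higher from compound 2 to compound 3 (within the scatter). Within the data shown here, it replaces hydrogen with chloro, and no measured compound carries benzyl. The step expected in this assay is therefore small, an estimated a number 8 percentage points lower from compound 3 to compound 4 (within the scatter), with no shift beyond the scatter. For compound 4 the expected value is 34%, estimated to lie from 15% to 52%.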

Compound 4, percent of the compound remaining: 26%
Estimate against measurement, compound 4: 8 percentage points above; the range from low to high includes it.
By their numbers in this assay, from the lowest: compounds 4, 2 and 3 (each within the scatter of the next, the first and the last beyond it). At a limit, below all of these: compound 1.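

In this assay, the position on the five-membered aromatic ring now shows a shift beyond the scatter, which the chloro step alone had not: benzyl in place of 2-chlorophenyl gives a number 16 percentage points lower from compound 3 to compound 4 (beyond the scatter). Benzyl in place of phenyl gives a number 10 percentage points lower from compound 2 to compound 4 (within the scatter), so only the comparison with 2-chlorophenyl clears the scatter. Nothing at hand bears on a cause for these steps.

From the compounds shown here alone, whether a longer chain in place of benzyl would leave more or less of the compound remains open. So does the effect of an amine or a carboxylic acid on the benzyl ring.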